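Shortening the sulfanyl side chain: phenethyl to propyl

The source may report more compounds than this note shows. Statements on the series, on what has been measured and on what is new or still open speak of the compounds shown alone.

Going by the values given here, compound 2 `O=c1ccn([C@@H]2O[C@H](COP(=O)(O)OP(=O)(O)O)[C@@H](O)[C@H]2O)c(SCCc2ccccc2)n1` gives 2500 nM in an in vitro functional assay on 1321-N1 cells for agonist activity at P2Y purinoceptor 6 (Homo sapiens), read by scintillation proximity assay and inositol phosphate accumulation (a higher number here means that more compound is needed for the effect, a lower number that less compound is needed), and is the only compound of the pair with a numerical value. Compound 1 `Nc1nc(=O)ccn1[C@@H]1O[C@H](COP(=O)(O)O)[C@@H](O)[C@H]1O` gives > 100000 nM in this assay, which is a limit and not a number. The set so far therefore shows (the limit of > 100000 nM in this assay, at which 1 of the 2 values shown sits).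

Compound 3 `CCCSc1nc(=O)ccn1[C@@H]1O[C@H](COP(=O)(O)OP(=O)(O)O)[C@@H](O)[C@H]1O` is the next compound, differing from compound 2 by methyl in place of phenyl on a saturated chain carbon, two bonds along the chain from a sulfur. Among the compounds with values here, no step between measured compounds is available to calibrate this change, so only a modest shift in this assay is expected, in either direction and likely within the scatter. Compound 3 is expected to give about 2000 nM in this assay, between 500 nM and 8000 nM. The expected step is a 1.3-fold lower number from compound 2 to compound 3 (0.10 log units; within the scatter).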

Compound 3, half-maximal effective concentration: >= 100000 nM
Compound 3: only a limit was reported; the forecaster's own chance of this, stated with the estimate: 5%; middle value at least 50-fold (1.69 log units) from the limit.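

Putting methyl in place of phenyl on a saturated chain carbon, two bonds along the chain from a sulfur, gives an at least 40-fold higher number from compound 2 to compound 3 (1.60 log units; beyond the scatter) in this assay, so this position of the side chain does not tolerate the change. Compound 3 gives >= 100000 nM, which is a limit and not a number. Compound 2 therefore remains the only compound shown with a numerical value: the limit of >= 100000 nM in this assay, at which 1 of the 3 values shown sits.

From the compounds shown here alone, whether the phenyl ring itself or the length of the phenethylsulfanyl chain matters stays open. A benzylsulfanyl or a hexylsulfanyl side chain would separate the two.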